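Trifluoromethyl to fluoro: working notes on compound 4

A few compounds are considered here, and "the series" means these few. Any claim that something is new, unique, unknown or untested is made for them only; others in the source may bear on it.

Measured in a functional assay on MCF7 cells (Breast, Homo sapiens) for inhibition; on this read-out higher numbers stand for weaker inhibition of growth and lower numbers for stronger inhibition of growth:
compound 1 `Nc1ccc(-c2nc3ccc(F)cc3s2)cc1I`: < 10 nM (a limit)
compound 2 `Cc1cc(-c2nc3c(F)cccc3s2)ccc1N`: < 10 nM (a limit)
compound 3 `Nc1ccc(-c2nc3ccccc3s2)cc1C(F)(F)F`: 1500 nM

Among the compounds with values here, compound 3 carries the only true number in this set, 1500 nM. Compound 1 sits at a limit of the assay and not at a number. Compound 2 does the same. The position of the set is summed up as the limit of < 10 nM in this assay, at which 2 of the 3 values shown sit.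

Compound 4 `Nc1ccc(-c2nc3ccccc3s2)cc1F` is not yet measured. It carries fluoro in place of trifluoromethyl on an aromatic carbon, ortho to an amino group (fluoro in place of trifluoromethyl on an aromatic carbon). Within the data shown here, no two measured compounds differ in one place, so no measured step guides this change.

Starting from compound 3 at 1500 nM, a step towards stronger inhibition of growth, beyond the scatter, is expected in this assay. Its size is uncertain. The estimated step is a 38-fold lower number from compound 3 to compound 4 (1.57 log units; beyond the scatter). Compound 4 is expected at 40 nM, with an estimated range of 5 nM to 600 nM.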

Compound 4, concentration for 50% growth inhibition: < 10 nM
Compound 4: no number, only a limit; the forecaster's own chance of this, stated with the estimate: 30%; middle value at least 4.0-fold (0.60 log units) away from the limit.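

In this assay, within the data shown here, trifluoromethyl replaced by fluoro on the aromatic carbon ortho to an amino group gives an at least 150-fold lower number from compound 3 to compound 4 (2.17 log units; beyond the scatter), the first step that links two measured compounds. Compound 4 gives < 10 nM, which is a limit of the assay and not a number, so this step has a lower bound but no measured size. Among the compounds shown, only compound 3 stands off that limit, and the position clearly tolerates fluoro far better than trifluoromethyl in this read-out: the limit of < 10 nM in this assay, at which 3 of the 4 values shown sit.

Still open, going by these compounds, is how a chloro, methoxy or nitrile group at this position would compare with fluoro and with trifluoromethyl. With compound 4 at a limit, the remaining room for stronger inhibition of growth with fluoro also cannot be read.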